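This account rests on a few compounds, and the source may have more. Where it says the series, first, only, none or still open, it means among the compounds named here.

Measured compounds:

- Compound 1, `CCC(/C=C1\OC(=O)NC1=O)(CC)c1ccc(-c2ccc3cccc(F)c3c2)[nH]c1=O`: in an ADME assay on microsomes from liver (Homo sapiens) for metabolic stability (a lower number here means that the compound disappears faster, a higher number that the compound lasts longer), compound 1 gives 0.948 h.
- Compound 2, `CC(C)C(/C=C1\NC(=O)NC1=O)c1ccc(-c2ccc3cccc(F)c3c2)[nH]c1=O`: in this assay compound 2 reports only a limit, > 3 h.
- Compound 3, `O=C1NC(=O)/C(=C/C2(c3ccc(-c4ccc5cccc(F)c5c4)[nH]c3=O)CC2)O1`: in this assay compound 3 gives 2.48 h.

Compound 2 stands at the top of the numbers shown, but its entry is a limit of the assay and not a number; (the limit of > 3 h in this assay, at which 1 of the 3 values shown sits). Among the measured compounds shown here, no step between two of the measured compounds differs in a single place, so nothing here sets a scale for the change that follows.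

Compound 4, `CC(C)C(c1ccc(-c2ccc3cccc(F)c3c2)[nH]c1=O)C1NC(=O)NC1=O`, is not yet measured in this assay. It differs from compound 2 in one place: a group of 7 heavy atoms (3 carbon, 2 nitrogen, 2 oxygen; one five-membered non-aromatic ring with 2 hetero atoms) in place of a group of 8 heavy atoms (4 carbon, 2 nitrogen, 2 oxygen; one five-membered non-aromatic ring with 2 hetero atoms), on a saturated chain carbon bound to an aromatic carbon and a saturated chain carbon.

For the measured compounds named here, with only a limit for compound 2 and no comparable step among the measured compounds, the size of the step in this assay cannot be read from the data; the expectation is a modest move downward or none beyond the scatter. Compound 4 is expected to give 2.5 h, within 1 h to 6 h, which is an expected step of an at least 1.2-fold lower number from compound 2 to compound 4 (0.07 log units; that floor lies within the scatter).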

Compound 4, half-life: 0.578 h
Estimate against measurement, compound 4: 4.3-fold (0.64 log units) above; measured number below the stated range.
By their numbers in this assay, from the lowest: compounds 4 and 1 (each within the scatter of the next); then compound 3. At a limit, above all of these: compound 2.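

In this assay, this saturated chain carbon, bound to an aromatic carbon and a saturated chain carbon, proves sensitive to the group it carries: the 2,5-dioxoimidazolidin-4-yl group, with 2 double bonds outside aromatic rings, in place of the group of 8 heavy atoms with 3 such bonds, gives an at least 5.1-fold lower number from compound 2 to compound 4 (0.71 log units; beyond the scatter). Among the compounds shown here, this is the first step that differs in one place, so it gives a scale that the earlier compounds could not. That size is only a floor, because compound 2 carries a limit of the assay and not a number: the limit of > 3 h in this assay, at which 1 of the 4 values shown sits.

The compounds shown leave open which part of the change carries the step, the double bond or the count of heavy atoms. They also leave open how a carboxylic acid or an amine on this same carbon would read in this assay.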